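The source may report more compounds than this note shows. Statements on the series, on what has been measured and on what is new or still open speak of the compounds shown alone.

Working notes on the series. All compounds share the core shown for compound 1, `CCCCc1cnc(C(CCCC)Cc2ccc(-c3ccccc3C(=O)O)cc2)[nH]1`, with a chain carrying a substituent on the imidazole side. Measured in an in vitro functional assay on cells for agonist activity at Bombesin receptor subtype-3 (Homo sapiens), read by luminescence and calcium flux (on this read-out lower numbers stand for an effect already at smaller amounts and higher numbers for an effect only at larger amounts of compound), compound 1 gives 2660 nM. Compound 2, `CC(C)(C)CCc1cnc(CCc2ccc(-c3ccccc3C(=O)O)cc2)[nH]1`, has in this assay the lowest of the two numbers recorded; compound 2 gives 39 nM, and the number for compound 1 is higher by a margin beyond the scatter. Compound 3, `CCCCc1cnc(Cc2ccc(-c3ccccc3C(=O)O)cc2)[nH]1`, is recorded only as a limit, not a number. In this assay compound 3 gives > 10000 nM. Among the three results one is such a limit: the limit of > 10000 nM in this assay, at which 1 of the 3 values shown sits.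

Compound 4, `O=C(O)c1ccccc1-c1ccc(CCc2ncc(CC3CCCC3)[nH]2)cc1`, has not yet been measured. It differs from compound 2 in one place: cyclopentyl in place of neopentyl on a saturated chain carbon bound to an aromatic carbon. Going by the values given here, no measured pair isolates this change, so its size can only be anticipated. The group leaving and the group entering are matched in size; the entering group carries a ring where the leaving one has none. For compound 4 the expected value in this assay is 80 nM, with a range from 25 nM to 300 nM. The step this estimate means, a 2.1-fold higher number from compound 2 to compound 4 (0.31 log units; beyond the scatter), is expected to be small, at or near the scatter, in the direction of a somewhat higher number.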

Compound 4, half-maximal effective concentration: 133 nM
Compound 4: the middle estimate sits 1.7-fold (0.22 log units) below what was measured, within the range that was stated.
By their numbers in this assay, from the lowest: compound 2; then compound 4; then compound 1. At a limit, above all of these: compound 3.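

In this assay, going by these compounds alone, compounds 2 and 4 give the first pair that isolates this position, and the exchange of neopentyl for cyclopentyl on a saturated chain carbon bound to an aromatic carbon gives a 3.4-fold higher number from compound 2 to compound 4 (0.53 log units; beyond the scatter) as a modest step. The two groups match in heavy atoms and differ in that the entering group carries a five-membered ring, so at this position, in this one pair, a ring in place of an open chain at equal size is accompanied by a higher number, while compound 4 still gives 133 nM as a measurable value. Nothing measured here gives a property that accounts for this step.

Open, going by these compounds, is whether a cyclopropyl or cyclohexyl ring would give a step of similar size or whether the step depends on the size of the ring, and whether a ring holding an amine, such as piperidine, or an ether oxygen, such as tetrahydropyran, would be tolerated here. Also open, on these data alone, is how a longer chain in place of cyclopentylmethyl would read in this assay.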